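Adding a second methoxy to the pyrazole-side aryl of compound 1

The source may hold more compounds than are shown below. What is called first, only, known or untested is meant among the compounds shown, and "the series" means these compounds.

Of the compounds shown here, three sharing one core have been tested in a functional assay on ACHN cells (Homo sapiens) for cytotoxicity, read by sulforhodamine B assay, with a stated time of 48 h, tested at 1 uM; on this read-out lower numbers stand for a stronger effect and higher numbers for a weaker effect at the one concentration tested. Compound 1 `COc1ccc(-c2cc(/C=C/C(=O)c3ccc(N)cc3)[nH]n2)cc1` gives 71%, the lowest of the three numbers and therefore the strongest effect seen. Within the data shown here, compound 2 `COc1ccc(C(=O)/C=C/c2cc(-c3cc(OC)c(OC)c(OC)c3)n[nH]2)cc1` gives 105% and compound 3 `COc1cc(-c2cc(/C=C/C(=O)c3ccc(F)c(F)c3)[nH]n2)cc(OC)c1OC` gives 100%; the one measured step, a number 5 percentage points lower from compound 2 to compound 3 (within the scatter), changes only the aryl on the carbonyl carbon and lies within the scatter. The unmeasured compound 4 `COc1ccc(-c2cc(/C=C/C(=O)c3ccc(N)cc3)[nH]n2)cc1OC` differs from compound 1 by methoxy in place of hydrogen on an aromatic carbon, on the aryl attached to the core rather than on the carbonyl side. Among the measured compounds shown here, no measured step touches this place: compounds 2 and 3 carry a trimethoxyphenyl there but also differ from compound 1 on the carbonyl side, so their higher numbers cannot be traced to the methoxy groups alone. With no direct comparison, the change from compound 1 to compound 4 is expected to stay within the scatter, a number 7 percentage points higher from compound 1 to compound 4 (within the scatter). Compound 4 is therefore estimated at 78%, with a range from 55% to 100%.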

Compound 4, a percentage reported as activity, at one concentration (the size of the read-out at that concentration, not a potency): 88%
The estimate for compound 4 lay 10 percentage points below the measured number; the measured number falls inside the stated range.
By their numbers in this assay, from the lowest: compound 1; then compound 4; then compounds 3 and 2 (each within the scatter of the next).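

In this assay, methoxy in place of hydrogen on the aryl attached to the core gives a number 17 percentage points higher from compound 1 to compound 4 (beyond the scatter) and so a weaker effect at the one concentration tested. Among these compounds, compounds 2 and 3 could not show this, since they also differ from compound 1 on the carbonyl side, whereas compound 4 keeps that side unchanged and isolates the single added group. Nothing available explains why the number moves at this position.

The compounds shown leave open whether a hydroxyl group or a fluorine atom on this same carbon would move the number as methoxy does. They also leave open whether the step would hold with another aryl on the carbonyl side, such as the 3,4-difluorophenyl of compound 3.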